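The source may report more compounds than this note shows. Statements on the series, on what has been measured and on what is new or still open speak of the compounds shown alone.

Compound 2 `CC1=C(C(=O)CC(C)C)C(c2cccs2)NC(=O)N1` stands second highest of the three numbers in an assay on membranes from HEK293 cells for displacement of a labelled ligand from adenosine receptor A2b (Homo sapiens), read by scintillation counting, with a stated time of 30 min, tested at 1 uM (a lower number here means less inhibition, a higher number more inhibition at the concentration tested (going by the name of the read-out)), where compound 2 gives 43%. Its nearest neighbour is compound 3 `CC1=C(c2ncc(C)o2)C(c2cccs2)NC(=O)N1`, which in this assay gives 45%, and the farthest is compound 1 `CCCOC(=O)C1=C(C)NC(=S)NC1c1cccs1`, which gives 3%; compound 1 differs from compound 2 in more than one place, so its low number is noted without being traced to one change. Compound 4 `CCC(C)OC(=O)C1=C(C)NC(=O)NC1c1cccs1` differs from compound 2 by sec-butoxy in place of isobutyl on a carbonyl carbon. For the measured compounds named here, the one measured step at the same carbonyl carbon, a number 2 percentage points higher from compound 2 to compound 3 (within the scatter), replaced the same group by a ring and moved the number not at all beyond the scatter. That step does not involve an oxygen entering, so it bears on compound 4 only loosely. Compound 4 is therefore expected to lie near compound 2, with the estimated step of a number 10 percentage points lower from compound 2 to compound 4 (within the scatter) leaning slightly downward. The estimate for compound 4 in this assay is 33%, ranging from 8% to 55%.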

Compound 4, a percentage reported as inhibition, at one concentration (the size of the read-out at that concentration, not a potency): 7%
Estimate against measurement, compound 4: 26 percentage points above; the measured number lies below the stated range.
By their numbers in this assay, from the lowest: compounds 1 and 4 (each within the scatter of the next); then compounds 2 and 3 (each within the scatter of the next).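

In this assay, the carbonyl carbon proves sensitive to what it carries: sec-butoxy in place of isobutyl gives a number 36 percentage points lower from compound 2 to compound 4 (beyond the scatter). The earlier step on the double-bonded ring carbon, a number 2 percentage points higher from compound 2 to compound 3 (within the scatter), exchanged the whole isobutylcarbonyl for 5-methyl-1,3-oxazol-2-yl, so a change here need not lower the number, yet one that keeps the carbonyl can lower it sharply. Nothing available accounts for the drop.

The compounds shown leave open whether the drop follows the oxygen that enters or the way the chain is branched, as this single change alters both at once. Also open, going by these compounds, is how a straight ethoxy chain or an amine on the same carbonyl carbon would read in this assay.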